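From compound 1 to compound 4: a side-chain exchange

A few compounds are considered here, and "the series" means these few. Any claim that something is new, unique, unknown or untested is made for them only; others in the source may bear on it.

Measured in a toxicity assay on MT2 cells (Homo sapiens) for cytotoxicity, read by XTT assay, with a stated time of 4 days; on this read-out lower numbers stand for higher toxicity in this test and higher numbers for lower toxicity in this test
compound 1 `Cc1nc(C)c([C@H](OC(C)(C)C)C(=O)O)c(N2CCC(C)(C)CC2)c1-c1ccc(OCCCc2ccc(F)cc2)cc1` gives >= 32000 nM (a limit)
compound 2 `Cc1nc(C)c([C@H](OC(C)(C)C)C(=O)O)c(N2CCC(C)(C)CC2)c1-c1ccc(OCCc2cccnc2)cc1` gives >= 25000 nM (a limit)
compound 3 `Cc1ncsc1CCOc1ccc(-c2c(C)nc(C)c([C@H](OC(C)(C)C)C(=O)O)c2N2CCC(C)(C)CC2)cc1` gives >= 25000 nM (a limit)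

Compound 1 stands at >= 32000 nM in this assay, and this is a limit, not a number. The other two values are limits as well, with the limit of >= 32000 nM in this assay, at which 1 of the 3 values shown sits, and the limit of >= 25000 nM in this assay, at which 2 of the 3 values shown sit, making up the whole picture, so compound 1 has no rank within the set.

The next compound is compound 4 `Cc1nc(C)c(CCOc2ccc(-c3c(C)nc(C)c([C@H](OC(C)(C)C)C(=O)O)c3N3CCC(C)(C)CC3)cc2)s1`, still unmeasured. The change from compound 1 is 2,4-dimethyl-1,3-thiazol-5-yl in place of 4-fluorobenzyl on a saturated chain carbon, two bonds along the chain from an oxygen on an aromatic ring and it places 2,4-dimethyl-1,3-thiazol-5-yl where 4-fluorobenzyl stood.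

Among the compounds with values here, three measured steps bear on this. Within the data shown here, the first is a step that the two limits leave unreadable from compound 1 to compound 3 and brings in 4-methyl-1,3-thiazol-5-yl. The second is a step that the two limits leave unreadable from compound 1 to compound 2 and brings in pyridin-3-yl. The third is a step that the two limits leave unreadable from compound 2 to compound 3 and links those two replacements. None of them has a readable size, and none of the three compounds reached a number in this assay.

On that basis, no step beyond the scatter is expected, in either direction, and the expected result is a number no higher from compound 1 to compound 4 (the limit leaves the size open) here. The estimate for compound 4 is 32000 nM with an expected range of 15000 nM to 60000 nM and a limit is the likely form of the report.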

Compound 4, half-maximal cytotoxic concentration: >= 25000 nM
Compound 4: only a limit was reported; the forecaster's own chance of this, stated with the estimate: 85%; the middle value is on the limit's open side.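

In this assay compound 4 gives >= 25000 nM, which is a limit and not a number. Within the data shown here, with limits on both sides, no step to compound 4 from compound 1, compound 2 or compound 3 can be read. The compounds shown leave open where the half-maximal cytotoxic concentration of any of the four lies, and whether any of these side-chain exchanges shifts it.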